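Shifting a Fluorine Atom: Expected Effect on Cytotoxicity

The source may hold more compounds than are shown below. What is called first, only, known or untested is meant among the compounds shown, and "the series" means these compounds.

Measured compounds:
Compound 1, `NS(=O)(=O)c1ccc(N2N=C(c3ccc(OCc4ccccc4)cc3)CC2c2ccc(F)cc2)cc1`, gives 90000 nM in an ADME assay on Vero 76 cells (Chlorocebus sabaeus) for cytotoxicity, read by MTT assay, with a stated time of 96 h; on this read-out lower numbers stand for higher toxicity in this test and higher numbers for lower toxicity in this test.
Compound 2, `NS(=O)(=O)c1ccc(N2N=C(c3ccc(Oc4ccccc4)cc3)CC2c2ccc(F)cc2)cc1`, gives 25000 nM in this assay.
Compound 3, `NS(=O)(=O)c1ccc(N2N=C(c3ccc(OCc4ccccc4)cc3)CC2c2ccccc2F)cc1`, gives > 100000 nM in this assay, which is a limit of the test and not a number.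

Compound 2 holds the lowest of the two numbers shown. Within the data shown here, the only other number comes from the step of a 3.6-fold lower number from compound 1 to compound 2 (0.56 log units; beyond the scatter), which went with phenyl in place of benzyl on an oxygen on an aromatic ring.

Compound 4, `NS(=O)(=O)c1ccc(N2N=C(c3ccc(Oc4ccccc4)cc3)CC2c2cccc(F)c2)cc1`, has not yet been measured. It differs from compound 2 by 3-fluorophenyl in place of 4-fluorophenyl on a saturated ring carbon. One measured step moves the same fluorophenyl group, an at least 1.1-fold higher number from compound 1 to compound 3 (0.04 log units; that floor lies within the scatter), and there the floor of the change lies within the scatter. That step ends at a limit: the limit of > 100000 nM in this assay, at which 1 of the 3 values shown sits.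

On this basis the expected step of a 1.2-fold higher number from compound 2 to compound 4 (0.08 log units; within the scatter) in this assay is none beyond the scatter. Compound 4 is therefore estimated at 30000 nM, with a range from 12000 nM to 70000 nM.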

Compound 4, half-maximal cytotoxic concentration: 28000 nM
Compound 4: middle estimate off by 1.1-fold (0.03 log units), on the high side, and the stated range covers the measured number.
By their numbers in this assay, from the lowest: compounds 2 and 4 (each within the scatter of the next); then compound 1. At a limit, above all of these: compound 3.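

In this assay, putting 3-fluorophenyl in place of 4-fluorophenyl on the saturated ring carbon gives a 1.1-fold higher number from compound 2 to compound 4 (0.05 log units; within the scatter), so this fluorine move now has a size read between two real numbers, and the test cannot tell the two compounds apart. The earlier fluorine move, to 2-fluorophenyl, could give no such size, because it ended at a limit of the test: the limit of > 100000 nM in this assay, at which 1 of the 4 values shown sits. With phenyl on the oxygen, then, the fluorine can sit at either of these two ring places without a readable difference, though this rests on a single pair of compounds.

From the compounds shown here alone, whether 2-fluorophenyl or 3-fluorophenyl would behave the same way with the other group on the oxygen remains open. So does the effect of a different group at this carbon, such as plain phenyl, a chlorophenyl or a methoxyphenyl.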